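The compounds below may be only part of what the source reports. "The series", "measured", "known", "first", "only" and "open" are said of these compounds alone.

The compounds in this set share one core, seen in compound 1 `CC(=O)Nc1ccc(S(=O)(=O)NNC(=O)c2cccnc2Nc2ccc(Cl)cc2)cc1`. In a functional assay on MDA-MB-435 cells (Homo sapiens) for antiproliferative activity (on this read-out lower numbers stand for higher toxicity in this test and higher numbers for lower toxicity in this test), compound 1 gives > 100000 nM, which is a limit of the test rather than a measured number. Compound 2 `O=C(NNS(=O)(=O)c1ccc(F)cc1)c1cccnc1Nc1ccc(Cl)cc1Cl` is the other compound already tested. In this assay compound 2 gives > 100000 nM, again a limit and not a number. So both measured values sit at the limit of > 100000 nM in this assay, at which 2 of the 2 values shown sit, and no step between two measured compounds can be drawn from them. Compound 3 `O=C(NNS(=O)(=O)c1ccc(Cl)cc1Cl)c1cccnc1Nc1ccc(Cl)cc1` has not yet been tested in this assay. It differs from compound 1 by 2,4-dichlorophenyl in place of 4-acetamidophenyl on a sulfonyl sulfur, in words 2,4-dichlorophenyl in place of 4-acetamidophenyl on a sulfonyl sulfur. With compound 1 at the limit and compound 2 at the limit as well, nothing measured shows that a swap at this place moves the number, so the step from compound 1 to compound 3 is expected to be none beyond the scatter, a number no higher from compound 1 to compound 3 (the limit leaves the size open). Compound 3 is therefore estimated at 100000 nM in this assay, within a range from 30000 nM to 300000 nM, and most likely it too will come back only as a limit.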

Compound 3, concentration lethal to 50% of the cells: > 100000 nM
Compound 3 gave a limit, no number; the forecaster's own chance of this, stated with the estimate: 80%; the middle value lies on the limit itself.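

Compound 3 gives > 100000 nM in this assay, which is a limit and not a number, so the step between compound 1 and compound 3 cannot be read. The compounds shown leave open whether any swap on the sulfonyl sulfur can shift the result at all, as all of them share one value: the limit of > 100000 nM in this assay, at which 3 of the 3 values shown sit.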